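Dibromopyridinyl amide in a cyclopentyloxy-methoxybenzamide series

The source may hold more compounds than are shown below. What is called first, only, known or untested is meant among the compounds shown, and "the series" means these compounds.

Measured so far in an assay on isolated protein for inhibition of phosphodiesterase 4A (Sus scrofa); on this read-out higher numbers stand for weaker inhibition and lower numbers for stronger inhibition:
compound 1 `COc1ccc(C(=O)Nc2c(F)cccc2F)cc1OC1CCCC1` gives 70 nM
compound 2 `COc1ccc(C(=O)Nc2c(F)cccc2Cl)cc1OC1CCCC1` gives 240 nM
compound 3 `COc1ccc(C(=O)Nc2cnccn2)cc1OC1CCCC1` gives 250 nM

Compound 3 stands at the highest number of the three; its value and that of compound 2 lie within the scatter of each other, while compound 1 sits clearly lower, as a 3.6-fold higher number from compound 1 to compound 3 (0.55 log units; beyond the scatter) shows. Compound 4 `COc1ccc(C(=O)Nc2c(Br)cncc2Br)cc1OC1CCCC1` differs from compound 3 in one place: 3,5-dibromopyridin-4-yl in place of pyrazin-2-yl on an amide-type nitrogen. The change echoes compound 1 and compound 2, which both carry two halogens on the amide-bound ring; a 3.6-fold higher number from compound 1 to compound 3 (0.55 log units; beyond the scatter) and a 1.0-fold higher number from compound 2 to compound 3 (0.02 log units; within the scatter) bracket the effect of such rings against the pyrazinyl, and a 3.4-fold higher number from compound 1 to compound 2 (0.54 log units; beyond the scatter) shows that a heavier halogen cost a modest amount. Compound 4 is therefore expected to give a lower number than compound 3 in this assay, a step of about a 5.0-fold lower number from compound 3 to compound 4 (0.70 log units; beyond the scatter), with an estimated value of 50 nM and a range from 10 nM to 250 nM.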

Compound 4, half-maximal inhibitory concentration: 7 nM
Estimate against measurement, compound 4: 7.1-fold (0.85 log units) above; the measured number lies below the stated range.
By their numbers in this assay, from the lowest: compound 4; then compound 1; then compounds 2 and 3 (each within the scatter of the next).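

In this assay, for the compounds shown here, the place on the amide-type nitrogen proves far more responsive than the earlier compounds showed: 3,5-dibromopyridin-4-yl in place of pyrazin-2-yl gives a 36-fold lower number from compound 3 to compound 4 (1.55 log units; beyond the scatter), and the same group also gives a 34-fold lower number from compound 2 to compound 4 (1.54 log units; beyond the scatter) and a 10-fold lower number from compound 1 to compound 4 (1.00 log units; beyond the scatter). The rise seen with chloro in place of fluoro therefore gives no general rule for heavier halogens on the amide-bound ring, since compound 4 carries bromine and a ring nitrogen together. Nothing shown gives a reason for this gain. As far as these compounds go, it remains open whether the bromines or the ring nitrogen carry the gain, and a 2,6-dibromophenyl or a 3,5-dichloropyridin-4-yl group on the amide-type nitrogen would separate the two.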